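Swapping the amide substituent in an acrylamide series

The source may report more compounds than this note shows. Statements on the series, on what has been measured and on what is new or still open speak of the compounds shown alone.

Among the measured compounds shown here, compound 1 `C=CC(=O)N1CC(NC(=O)Cn2cc(C(=O)N(C)Cc3ccccc3)c3cc(Br)ccc32)C1` is one of three compounds measured in a physicochemical assay for pharmacokinetics, read by LC-MS, in phosphate buffer, at pH 7.4, in the presence of a further agent that is not named here (a higher number here means that the compound lasts longer, a lower number that the compound disappears faster), where compound 1 gives 1.67 h. Compound 2 `C=CC(=O)N1CC(NC(=O)Cn2ccc3cc(Br)ccc32)C1` gives 1.67 h and compound 3 `C=CC(=O)N1CC(NC(=O)COc2ccc(Br)cc2C(=O)N2CC=C(c3ccccc3)C2)C1` gives 1.67 h, so compound 1 stands level with both of them within the scatter, and none of the three can be called longer- or shorter-lived than another. The new compound 4 `C=CC(=O)N1CC(NC(=O)Cn2cc(C(=O)N3CCc4c(cccc4OC)C3)c3cc(Br)ccc32)C1` differs from compound 1 in one place: a group of 12 heavy atoms (10 carbon, 1 nitrogen, 1 oxygen; one six-membered non-aromatic ring with 1 hetero atom, one six-membered aromatic ring of carbon only) in place of a group of 9 heavy atoms (8 carbon, 1 nitrogen; one six-membered aromatic ring of carbon only), on a carbonyl carbon. For the measured compounds named here, only one measured step bears on this part of the molecule, no change at the digits printed from compound 1 to compound 2 (within the scatter); there the benzyl(methyl)carbamoyl group was exchanged for hydrogen and the half-life did not move beyond the scatter. Replacing the same substituent with a larger one is therefore expected to leave the half-life where it is, with no step beyond the scatter, which means an estimated no change at the digits printed from compound 1 to compound 4 (within the scatter). Compound 4 is expected to give 1.67 h, with a likely range from 0.9 h to 3.1 h.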

Compound 4, half-life: 1.67 h
For compound 4 middle estimate and measured number coincide at the digits printed; the measured number falls inside the stated range.
By their numbers in this assay, from the lowest: compounds 1, 2, 3 and 4 (each within the scatter of the next).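

In this assay, the earlier step at this part of the molecule only took the benzyl(methyl)carbamoyl group away, whereas the new step puts a larger group on the same carbonyl carbon, and the half-life shows no change at the digits printed from compound 1 to compound 4 (within the scatter). The half-life of this pair therefore stays within the scatter even though the entering group brings a six-membered non-aromatic ring and a hydrogen-bond acceptor that benzyl(methyl)amino does not have. No measurement shown here offers an explanation for this flat result.

The groups shown on this carbonyl carbon all carry no net charge and all hold a six-membered aromatic ring of carbon only. From the compounds shown here alone, whether an amine or a carboxylic acid in that group would also leave the half-life level remains open.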